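This account rests on a few compounds, and the source may have more. Where it says the series, first, only, none or still open, it means among the compounds named here.

Notes on the series in a functional assay on the whole organism for inhibition, with Rattus norvegicus as the target; on this read-out lower numbers stand for an effect already at smaller amounts and higher numbers for an effect only at larger amounts of compound: compound 1 `CC(Cc1ccc(Cl)cc1)(Oc1ccc(Cc2ccccc2)cc1)C(=O)O` gives 1 mg/kg, the only actual number so far. Compound 2 `COc1ccc(Cc2ccc(OC(C)(Cc3ccc(Cl)cc3)C(=O)O)cc2)cc1` is reported only as a limit, < 10 mg/kg. Compound 3 `CC(Cc1ccc(Cl)cc1)(Oc1ccc(C2CCSCC2)cc1)C(=O)O` is also reported only as a limit, < 10 mg/kg.

The next compound is compound 4 `CC(Cc1ccc2c(c1)CCC2)(Oc1ccc(Cc2ccccc2)cc1)C(=O)O`, with 2,3-dihydro-1H-inden-5-yl in place of 4-chlorophenyl on a saturated chain carbon (2,3-dihydro-1H-inden-5-yl in place of 4-chlorophenyl on a saturated chain carbon, two bonds along the chain from a carbonyl carbon and an oxygen on an aromatic ring).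

Three measured steps are available, and none has a readable size: a step that the limit leaves unreadable from compound 1 to compound 2, a step that the limit leaves unreadable from compound 1 to compound 3 and a step that the two limits leave unreadable from compound 2 to compound 3. All three change the group on the aromatic carbon, and none touches the 4-chlorophenyl group, so the series gives no measure of this change. Compound 1 at 1 mg/kg is therefore the only anchor, and no direction can be favoured.

In this assay, the expected result is no shift beyond the usual scatter, with an estimated 1.5-fold higher number from compound 1 to compound 4 (0.18 log units; within the scatter). The estimate for compound 4 is 1.5 mg/kg, with an expected range of 0.4 mg/kg to 6 mg/kg.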

Compound 4, dose for half-maximal effect: 0.5 mg/kg
For compound 4 the middle estimate is 3.0-fold (0.48 log units) above the measured one, within the range that was stated.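

In this assay, for the compounds shown here, this is the first readable step, and the first change at the saturated chain carbon, two bonds along the chain from a carbonyl carbon and an oxygen on an aromatic ring: a 2.0-fold lower number from compound 1 to compound 4 (0.30 log units; within the scatter). Replacing 4-chlorophenyl with 2,3-dihydro-1H-inden-5-yl removes the chlorine and adds a five-membered non-aromatic ring of carbon only, yet the step stays within the scatter. With the benzyl group unchanged, chlorine is therefore not required at this place for a value of this size.

Still open, as far as these compounds go, is how a pyridine ring, a plain phenyl or an open alkyl chain would read at this place. The steps among compounds 1, 2 and 3 cannot be read, so the change on the aromatic carbon has no size: the limit of < 10 mg/kg in this assay, at which 2 of the 4 values shown sit.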